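A few compounds are considered here, and "the series" means these few. Any claim that something is new, unique, unknown or untested is made for them only; others in the source may bear on it.

In a toxicity assay on MDCK cells (Canis lupus familiaris) for cytotoxicity, read by crystal violet staining, with a stated time of 48 h (a lower number here means that less compound is tolerated, a higher number that more compound is tolerated), compound 1, `CCc1ccc2[nH]c(=O)c(CN(Cc3ccc(C(C)(C)C)cc3)C(C)c3ccc(F)cc3)cc2c1`, gives 2800 nM. Compound 2, `CC(C)c1ccc2[nH]c(=O)c(CN(Cc3ccc(C(C)(C)C)cc3)C(C)c3ccc(F)cc3)cc2c1`, differs from compound 1 by methyl in place of hydrogen on a saturated chain carbon bound to an aromatic carbon and a saturated chain carbon, and in this assay compound 2 gives 13100 nM, so that a 4.7-fold higher number from compound 1 to compound 2 (0.67 log units; beyond the scatter). Compound 3, `Cc1ccc2[nH]c(=O)c(CN(Cc3ccc(C(C)(C)C)cc3)[C@H](C)c3ccc(F)cc3)cc2c1`, shows only a limit in this assay, > 5000 nM. That value is the limit of > 5000 nM in this assay, at which 1 of the 3 values shown sits. How the core of compound 3 differs from the core of compound 1 is not broken down here. Compound 4, `CCc1ccc2[nH]c(=O)c(CN(Cc3ccc(C(C)(C)C)cc3)[C@H](C)c3ccc(F)cc3)cc2c1`, has not yet been measured in this assay; it differs from compound 3 by methyl in place of hydrogen on a saturated chain carbon bound to an aromatic carbon. Going by the values given here, this is the same kind of change as the one from compound 1 to compound 2, though not the same: there the carbon was bound to an aromatic carbon and a saturated chain carbon, here only to an aromatic carbon. The expected step is an at least 1.2-fold lower number from compound 3 to compound 4 (0.09 log units; that floor lies within the scatter), since compound 1 gives 2800 nM in this assay and compound 4 carries the same ethyl group. For compound 4 the estimate is 4000 nM, with a likely range from 1800 nM to 9000 nM.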

Compound 4, half-maximal cytotoxic concentration: > 5000 nM
Compound 4 ended at the assay's limit (the forecaster's own chance of this, stated with the estimate: 35%); middle value at least 1.2-fold (0.09 log units) away from the limit.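

The step from methyl to ethyl between compound 3 and compound 4 cannot be read in this assay, and neither can any comparison of it with an earlier step, because both compounds stand at a limit of the assay and not at a number: the limit of > 5000 nM in this assay, at which 2 of the 4 values shown sit. The earlier result, a 4.7-fold higher number from compound 1 to compound 2 (0.67 log units; beyond the scatter), is therefore neither confirmed nor contradicted on the core of compound 3, so nothing here shows that this change carries over from one core to another, or that it fails to. Going by these compounds alone, the one readable new step is an at least 1.7-fold higher number from compound 1 to compound 4 (0.25 log units; that floor lies within the scatter), and it concerns only how a stereocentre is drawn, not any added atom: the fact that one of compounds 1 and 4 is drawn with a defined configuration and the other without, at the place where they differ.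

Still open, going by these compounds, is where compound 3 and compound 4 would lie if each gave a number rather than a limit, and how the opposite configuration would behave. Also open, on these data alone, is what an amine or a longer chain in place of the ethyl group would give in this assay.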